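A few compounds are considered here, and "the series" means these few. Any claim that something is new, unique, unknown or untested is made for them only; others in the source may bear on it.

Of the compounds shown here, three built on one shared core have been tested in a functional assay on HeLa cells (Homo sapiens) for antiproliferative activity, read by MTT assay, with a stated time of 48 h; on this read-out higher numbers stand for weaker inhibition and lower numbers for stronger inhibition. Compound 1 `COc1cc(-c2nnc(SCC(=O)c3ccc(Br)cc3)n2N)cc(OC)c1OC` gives 10400 nM, compound 2 `COc1cc(-c2nnc(SCC(=O)c3ccc(C(F)(F)F)cc3)n2N)cc(OC)c1OC` gives 3380 nM, and compound 3 `COc1ccc(C(=O)CSc2nnc(-c3cc(OC)c(OC)c(OC)c3)n2N)cc1` gives 17400 nM. Compound 2 has the lowest number of the three, as seen in a 3.1-fold lower number from compound 1 to compound 2 (0.49 log units; beyond the scatter) and in a 5.1-fold higher number from compound 2 to compound 3 (0.71 log units; beyond the scatter). Compound 4 `COc1cccc(NC(=O)CSc2nnc(-c3cc(OC)c(OC)c(OC)c3)n2N)c1` is not yet measured; it differs from compound 2 by (3-methoxyphenyl)amino in place of 4-(trifluoromethyl)phenyl on a carbonyl carbon. Among the compounds with values here, no measured step exchanges the whole group on the carbonyl carbon, so only the exchanges on the aromatic ring bear on it: a 5.1-fold higher number from compound 2 to compound 3 (0.71 log units; beyond the scatter) and a 1.7-fold higher number from compound 1 to compound 3 (0.22 log units; within the scatter) show that leaving trifluoromethyl went with higher numbers. A step of a 4.4-fold higher number from compound 2 to compound 4 (0.65 log units; beyond the scatter) towards a higher number is therefore expected. Compound 4 is estimated at 15000 nM, within 5000 nM to 50000 nM.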

Compound 4, half-maximal inhibitory concentration: 4020 nM
Compound 4: middle estimate off by 3.7-fold (0.57 log units), on the high side, and the stated range ends above it.
By their numbers in this assay, from the lowest: compounds 2 and 4 (each within the scatter of the next); then compounds 1 and 3 (each within the scatter of the next).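

Trifluoromethyl is not required to reach the lowest level seen so far: the whole 4-(trifluoromethyl)phenyl group on the carbonyl carbon can give way to (3-methoxyphenyl)amino, with a 1.2-fold higher number from compound 2 to compound 4 (0.08 log units; within the scatter). The same kind of exchange gives lower numbers than the other two groups, with a 4.3-fold lower number from compound 3 to compound 4 (0.64 log units; beyond the scatter) and with a 2.6-fold lower number from compound 1 to compound 4 (0.41 log units; beyond the scatter). No measured evidence explains these results.

The compounds shown do not separate the contribution of the amide hydrogen from that of the methoxy group on the ring. As far as these compounds go, how a morpholine or a simple cyclohexylamino group on the carbonyl carbon would read also remains open.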